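A few compounds are considered here, and "the series" means these few. Any claim that something is new, unique, unknown or untested is made for them only; others in the source may bear on it.

Compound 2, `Cc1cc(C(=O)O)nn1Cc1cc(Br)ccc1OCc1ccc(F)cc1`: 11.8 nM
Compound 1, `O=C(O)c1nn(Cc2cc(Br)ccc2OCc2ccccc2)cc1Br`: < 2000 nM

Among the compounds with values here, in a functional assay on CHO-K1 cells for antagonist activity at prostaglandin E2 receptor EP1 subtype (Homo sapiens), read by FLIPR (a lower number here means a stronger inhibitor, a higher number a weaker inhibitor), compound 2 gives 11.8 nM, the only full number among the two values here. For compound 1 the result is only a limit of the assay, < 2000 nM, at which the limit of < 2000 nM in this assay, at which 1 of the 2 values shown sits, sits. Compound 3, `Cc1cc(C(=O)O)nn1Cc1cc(Br)ccc1OCc1cc(Cl)cc(Cl)c1`, differs from compound 2 by 3,5-dichlorophenyl in place of 4-fluorophenyl on a saturated chain carbon bound to an oxygen on an aromatic ring. Within the data shown here, no measured step between two compounds is available to set the size of this change, so the expected step of a 1.7-fold higher number from compound 2 to compound 3 (0.23 log units; within the scatter) is small and may well fall within the usual scatter. Compound 3 is estimated at 20 nM, with a range from 5 nM to 80 nM.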

Compound 3, inhibition constant: 1120 nM
Compound 3: the middle estimate sits 56-fold (1.75 log units) below what was measured, and the stated range ends below it.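

In this assay, 3,5-dichlorophenyl in place of 4-fluorophenyl on a saturated chain carbon bound to an oxygen on an aromatic ring gives a 95-fold higher number from compound 2 to compound 3 (1.98 log units; beyond the scatter), so this place does not treat these two substituted phenyl groups alike. Compound 1 and compound 2 differ in more than one place and could set no size for any single change. Nothing given here accounts for this step. Going by these compounds, whether the two chlorines themselves or the places they occupy drive the step stays open. So does how a phenyl ring bearing a single chlorine, or a pyridine ring, would read here.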